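From phenylsulfonyl to (4-chlorophenyl)sulfonyl: an open step

This account rests on a few compounds, and the source may have more. Where it says the series, first, only, none or still open, it means among the compounds named here.

Measured in a functional assay on MDA-MB-231 cells (Homo sapiens) for antiproliferative activity, read by sulforhodamine B assay, with a stated time of 72 h; a lower number here means a stronger inhibitor, a higher number a weaker inhibitor:
- compound 1 `Cc1ccc(S(=O)(=O)Nc2cc(SCCC(=O)N[C@@H](CC(C)C)B(O)O)c(O)c3ccccc23)cc1`: 6150 nM
- compound 2 `CC(C)C[C@H](NC(=O)CCSc1cc(NS(=O)(=O)c2ccccc2)c2ccccc2c1O)B(O)O`: 4200 nM

Compound 2, at 4200 nM, stands within the scatter of compound 1, at 6150 nM, so neither can be ranked above the other. Compound 3 `CC(C)C[C@H](NC(=O)CCSc1cc(NS(=O)(=O)c2ccc(Cl)cc2)c2ccccc2c1O)B(O)O` is not yet measured. It differs from compound 2 by chloro in place of hydrogen on an aromatic carbon, which turns phenylsulfonyl into (4-chlorophenyl)sulfonyl. Among the measured compounds shown here, only one measured step bears on this change. It is a 1.5-fold lower number from compound 1 to compound 2 (0.17 log units; within the scatter), where hydrogen takes the place of methyl on an aromatic carbon, and it stays within the scatter. For the measured compounds named here, one small step is thin evidence, and no chloro compound has been measured yet. No step beyond the scatter is therefore expected in this assay. The expected change is a 1.1-fold lower number from compound 2 to compound 3 (0.02 log units; within the scatter). Compound 3 is estimated at 4000 nM, with an expected range of 1800 nM to 9000 nM.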

Compound 3, half-maximal inhibitory concentration: 4090 nM
Beside the measured number, compound 3's estimate is 1.0-fold (0.01 log units) below it, and the stated range covers the measured number.
By their numbers in this assay, from the lowest: compounds 3, 2 and 1 (each within the scatter of the next).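

In this assay, the place para to a large group on the six-membered aromatic ring has now been read with a third substituent, and a halogen joins hydrogen and methyl there. Chloro in place of hydrogen gives a 1.0-fold lower number from compound 2 to compound 3 (0.01 log units; within the scatter) and chloro in place of methyl gives a 1.5-fold lower number from compound 1 to compound 3 (0.18 log units; within the scatter) and so, across these three groups, no step at this place leaves the scatter and none of them can be ranked above another. Nothing in the data given here offers an explanation for this result.

The compounds shown leave open whether a group of another kind at this place, such as an amine, a carboxylic acid or methoxy, would give a step beyond the scatter. They also leave open whether chloro would behave the same way elsewhere on this ring.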